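Methyl on the Fused Ring: From Compound 2 to Compound 3

A few compounds are considered here, and "the series" means these few. Any claim that something is new, unique, unknown or untested is made for them only; others in the source may bear on it.

Of the compounds shown here, two have been measured in a functional assay on the whole organism (strain Sprague-Dawley) for inhibition, with Rattus norvegicus as the target, read by paw edema, with stated times of 1 h and 3 h, at a dose of 50 mg/kg by the oral route; on this read-out higher numbers stand for more inhibition at the one dose given (going by the name of the read-out) and lower numbers for less inhibition. Compound 1 `Cc1ccn2c(C(=O)c3sc(N)nc3N(C)C)cnc2c1` gives 85% in this assay. Compound 2 `Cc1nc(N)sc1C(=O)c1cnc2ccccn12` gives 53% in this assay, which places compound 2 lowest of the two numbers, with compound 1 standing beyond the scatter above it. Within the data shown here, compound 1 and compound 2 differ in more than one place, so their two values show only that the pair sits apart, not which change carries the gap.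

Compound 3 `Cc1ccn2c(C(=O)c3sc(N)nc3C)cnc2c1` has not yet been measured in this assay. It arises from compound 2 by a single change, (methyl in place of hydrogen on an aromatic carbon), and it carries the methylated fused core of compound 1 together with the methyl-bearing second ring of compound 2.

Among the measured compounds shown here, since no measured pair isolates this change, the writer expects for this assay a modest rise from compound 2 to compound 3, a step of a number 10 percentage points higher from compound 2 to compound 3 (within the scatter), which may well remain within the scatter. Compound 3 is accordingly estimated at 63% in this assay, with a range from 45% to 80%.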

Compound 3, a percentage reported as inhibition, in the whole organism at one dose (the size of the read-out at that dose, not a potency): 66%
Estimate against measurement, compound 3: 3 percentage points below; the measured number falls inside the stated range.
By their numbers in this assay, from the lowest: compound 2; then compound 3; then compound 1.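

In this assay, methyl in place of hydrogen on an aromatic carbon of the fused system, opposite the ring nitrogen, gives a number 13 percentage points higher from compound 2 to compound 3 (beyond the scatter), which shows that this position responds to the change, something the pair of compound 1 and compound 2 could not show because they differ in more than one place. Compound 3 also links to compound 1 through a single change, methyl in place of dimethylamino on an aromatic carbon, with a number 19 percentage points lower from compound 1 to compound 3 (beyond the scatter), so the separation between compound 1 and compound 2 can now be read as two single steps, each beyond the scatter. Nothing available here accounts for either step.

The compounds shown leave open whether a longer chain such as ethyl, or a methoxy group, at the same place on the fused system would move the read-out further than methyl does. They also leave open whether another amine, such as morpholine, could stand in for dimethylamino, and whether the methyl step would be of similar size with dimethylamino present.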